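The source may report more compounds than this note shows. Statements on the series, on what has been measured and on what is new or still open speak of the compounds shown alone.

Measured compounds:
Compound 1, `Cc1cnc(Nc2ccc(S(C)(=O)=O)cc2)nc1Nc1nc2ccc(Cl)cc2s1`, 4180 nM in a functional assay on HeLa cells (Homo sapiens) for antiproliferative activity, read by MTT assay, with a stated time of 48 h; on this read-out lower numbers stand for stronger inhibition and higher numbers for weaker inhibition
Compound 2, `Cc1cnc(Nc2ccc(S(C)(=O)=O)cc2)nc1Nc1nc2ccccc2s1`, 460 nM in this assay
Compound 3, `NS(=O)(=O)c1ccc(Nc2ncc(F)c(Nc3nc4ccccc4s3)n2)cc1`, 4520 nM in this assay

The three measured compounds share a general arrangement but two cores are present; how the core of compound 3 differs from that of compound 2 is not broken down here. Within the core of compound 2, one change is counted: chloro in place of hydrogen on an aromatic carbon. That change gave a 9.1-fold higher number from compound 2 to compound 1 (0.96 log units; beyond the scatter). Compound 3 stands close to compound 1, within the usual scatter, and far from compound 2.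

Compound 4, `NS(=O)(=O)c1ccc(Nc2ncc(F)c(Nc3nc4ccc(Cl)cc4s3)n2)cc1`, is not yet measured. It differs from compound 3 by chloro in place of hydrogen on an aromatic carbon, the same kind of change seen from compound 2 to compound 1. Because the earlier step was a 9.1-fold higher number from compound 2 to compound 1 (0.96 log units; beyond the scatter), a similar weakening is expected here: compound 4 is estimated to show a 5.5-fold higher number from compound 3 to compound 4 (0.74 log units; beyond the scatter), giving an expected 25000 nM (roughly 8000 nM to 80000 nM) in this assay.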

Compound 4, half-maximal inhibitory concentration: 8770 nM
For compound 4 the middle estimate is 2.9-fold (0.45 log units) above the measured one; measured number inside the range.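

Chloro in place of hydrogen on an aromatic carbon gave a 1.9-fold higher number from compound 3 to compound 4 (0.29 log units; within the scatter) in this assay, so on this core the change cannot be told apart from the scatter. The size of the step therefore did not carry over from one core to the other: the same change on two cores in this assay, a 9.1-fold higher number (0.96 log units; beyond the scatter) from compound 2 to compound 1 and a 1.9-fold higher number (0.29 log units; within the scatter) from compound 3 to compound 4, 4.7-fold (0.67 log units) apart, beyond the scatter of two such steps This shows that, for these two pairs, the step seen on one core is a poor guide to the step on the other, but with one pair per core it does not show which difference between the cores accounts for the gap.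

The compounds shown leave open how a group other than chloro, such as fluoro, methoxy or an amine, would behave at the same place on the two cores. They also leave open whether the gap would hold for chloro at the other ring carbons.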